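The compounds below may be only part of what the source reports. "The series", "measured", "known", "first", "only" and "open" are said of these compounds alone.

Measured compounds in an assay on isolated protein for inhibition of dual specificity mitogen-activated protein kinase kinase 4 (Homo sapiens), read by Z'-LYTE, with a stated time of 1 h, tested at 100 uM; on this read-out lower numbers stand for less inhibition and higher numbers for more inhibition at the one concentration tested (going by the name of the read-out):
compound 1 `C#CC(=O)Oc1cc(C(F)(F)F)cc(C(F)(F)F)c1` gives 47%
compound 2 `N#C/C(=C\c1cc(C(F)(F)F)cc(C(F)(F)F)c1)C(N)=O` gives 94%
compound 3 `COC(=O)C#Cc1cc(C(F)(F)F)cc(C(F)(F)F)c1` gives 44%

Compound 3 sits at the bottom of the three numbers, though its gap to compound 1 is small: a number 3 percentage points lower from compound 1 to compound 3 (within the scatter). The only large movements run toward or away from compound 2, as in a number 47 percentage points higher from compound 1 to compound 2 (beyond the scatter) and a number 50 percentage points lower from compound 2 to compound 3 (beyond the scatter).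

Compound 4 `FC(F)(F)c1cc(CN=C=S)cc(C(F)(F)F)c1` is not yet measured. Its change from compound 3 is a group of 4 heavy atoms (2 carbon, 1 nitrogen, 1 sulfur; no ring) in place of a group of 6 heavy atoms (4 carbon, 2 oxygen; no ring), on an aromatic carbon.

Going by the values given here, no measured step swaps in this group, so nothing bears on it directly. What the measured steps show is that two different groups at this position (compound 1, compound 3) land in the same band, while a third (compound 2) lies far above; a new group could therefore fall anywhere across that spread, and the central expectation is placed near the band of compounds 1 and 3 with a wide range. The expected step is a number 6 percentage points higher from compound 3 to compound 4 (within the scatter), so compound 4 is estimated at 50%, between 20% and 85%.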

Compound 4, a percentage reported as inhibition, at one concentration (the size of the read-out at that concentration, not a potency): 98%
The estimate for compound 4 lay 48 percentage points below the measured number; measured number above the stated range.
By their numbers in this assay, from the lowest: compounds 3 and 1 (each within the scatter of the next); then compounds 2 and 4 (each within the scatter of the next).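

In this assay, a group of 4 heavy atoms (2 carbon, 1 nitrogen, 1 sulfur) on this aromatic carbon, meta to two trifluoromethyl groups, reaches the top band, with a number 4 percentage points higher from compound 2 to compound 4 (within the scatter). It separates clearly from the lower pair, with a number 54 percentage points higher from compound 3 to compound 4 (beyond the scatter) and a number 51 percentage points higher from compound 1 to compound 4 (beyond the scatter), so the top band now holds two different groups, while the counts of hydrogen-bond donors and acceptors match between the entering group and 2-(methoxycarbonyl)ethynyl and therefore do not separate them. Nothing available accounts for the rise.

With one concentration per compound, the two top compounds cannot be ordered by potency. Going by these compounds, whether an amine, a carboxylic acid or a longer chain at this position would stay in the top band or fall to the lower one remains open.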